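Benzyloxy in place of allyloxy on a tetrabrominated diaryl ether

The compounds below may be only part of what the source reports. "The series", "measured", "known", "first", "only" and "open" are said of these compounds alone.

Three compounds built on the same tetrabrominated diaryl ether core have been tested in a functional assay on U-937 cells (Homo sapiens) for cytotoxicity, read by MTT assay, with a stated time of 24 h; a higher number here means a weaker inhibitor, a lower number a stronger inhibitor. Compound 1 `COc1ccccc1N1CCN(CCCCCOc2c(Br)cc(Br)cc2Oc2ccc(Br)cc2Br)CC1` gives 37.5 ug/mL in this assay. Compound 2 `OCCOc1c(Br)cc(Br)cc1Oc1ccc(Br)cc1Br` gives 34.5 ug/mL, and compound 3 `C=CCOc1c(Br)cc(Br)cc1Oc1ccc(Br)cc1Br` gives 29 ug/mL. Compound 3 thus shows the lowest of the three numbers, yet both others sit within the scatter of it, compound 2 nearer and compound 1 a little further off. Among the compounds with values here, the only single-place step recorded, a 1.2-fold lower number from compound 2 to compound 3 (0.08 log units; within the scatter), shows that replacing hydroxymethyl with vinyl on a saturated chain carbon bound to an oxygen on an aromatic ring left the readout essentially unchanged.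

Compound 4 `Brc1ccc(Oc2cc(Br)cc(Br)c2OCc2ccccc2)c(Br)c1` differs from compound 3 by phenyl in place of vinyl on a saturated chain carbon bound to an oxygen on an aromatic ring, allyloxy becoming benzyloxy. Within the data shown here, no measured step bears directly on a vinyl-to-phenyl exchange; the one step available concerned a different group at the same place and stayed within the scatter, while compound 1 differs from compound 3 in more than one place, so only its value can be set beside the others. Among the measured compounds shown here, with the sole comparable change having produced no clear movement, the step is expected to remain small, a 1.2-fold lower number from compound 3 to compound 4 (0.06 log units; within the scatter). Compound 4 is therefore estimated at 25 ug/mL, within a range from 12 ug/mL to 50 ug/mL.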

Compound 4, half-maximal inhibitory concentration: 29 ug/mL
For compound 4 the middle estimate is 1.2-fold (0.06 log units) below the measured one, and the stated range covers the measured number.
By their numbers in this assay, from the lowest: compounds 3, 4, 2 and 1 (each within the scatter of the next).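

At this place, on a saturated chain carbon bound to an oxygen on an aromatic ring, the comparison in this assay now reaches beyond an exchange of two open-chain groups: no change at the digits printed from compound 3 to compound 4 (within the scatter), and a 1.2-fold lower number from compound 2 to compound 4 (0.08 log units; within the scatter). Phenyl, with its six heavy atoms and one six-membered aromatic ring of carbon only, thus stays within the scatter of both vinyl and hydroxymethyl, whereas the earlier step had tested only vinyl against hydroxymethyl. Allyloxy, benzyloxy and the hydroxyl-bearing chain of compound 2 therefore cannot be told apart in this readout, and no measurement given here accounts for that.

On these data alone, whether an amine or a carboxylic acid at this same place, or a phenyl ring carrying a methoxy group, would move the number beyond the scatter remains open. The compounds shown also leave open whether the parity between vinyl, phenyl and hydroxymethyl would hold in cells other than those of this assay.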